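Notes on the series: fluoro in place of methoxy

A few compounds are considered here, and "the series" means these few. Any claim that something is new, unique, unknown or untested is made for them only; others in the source may bear on it.

Compound 1 `O=C(Nc1cccc(-c2nc3ccccc3s2)c1)c1cnccc1Cl` is the parent of the set. In an ADME assay on BJ cells (Homo sapiens) for inhibition, with a stated time of 72 h (on this read-out lower numbers stand for an effect already at smaller amounts and higher numbers for an effect only at larger amounts of compound), compound 1 gives only a limit, > 25000 nM. Compound 2 `COc1ccc(-c2nc3ccccc3s2)cc1NC(=O)c1cnccc1Cl` differs from it by a methoxy in place of hydrogen on an aromatic carbon; in this assay compound 2 likewise gives only a limit, > 25000 nM. The step that the two limits leave unreadable from compound 1 to compound 2 is therefore not readable in size or direction, because of the limit of > 25000 nM in this assay, at which 2 of the 2 values shown sit; both measured values sit at that limit and nothing more can be said of compound 2 than that it stands there.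

Compound 3 `O=C(Nc1cc(-c2nc3ccccc3s2)ccc1F)c1cnccc1Cl` carries the change (fluoro in place of methoxy on an aromatic carbon). Going by the values given here, no measured step bears on a fluoro in place of a methoxy at that position, and the one step recorded in this assay, from compound 1 to compound 2, is itself unreadable. The expectation for compound 3 in this assay is therefore that it again reports only a limit, with the step that the limit leaves unreadable from compound 2 to compound 3 expected to stay within the scatter. Compound 3 is estimated at 30000 nM, between 10000 nM and 100000 nM.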

Compound 3, half-maximal effective concentration: > 25000 nM
Compound 3: no number, only a limit; the forecaster's own chance of this, stated with the estimate: 85%; the middle value lies beyond the limit too.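

No step among compound 1, compound 2 and compound 3 can be read in this assay, because each gives only a limit and none gives a number: the limit of > 25000 nM in this assay, at which 3 of the 3 values shown sit.

The compounds shown leave open whether methoxy or fluoro in place of hydrogen on that aromatic carbon shifts the half-maximal effective concentration at all, and in which direction.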